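Extending an ester chain by one carbon: cytotoxicity on lung cells

The compounds below may be only part of what the source reports. "The series", "measured", "known", "first", "only" and "open" are said of these compounds alone.

Measured compounds:
- compound 1, `CCCCCOC(=O)CCC(=O)N1CCN(CCCOc2cc3c(Nc4ccc(F)c(Cl)c4)ncnc3cc2OC)CC1`: 63.6%
- compound 2, `CCCCCCCCCCCCCCOC(=O)CCC(=O)N1CCN(CCCOc2cc3c(Nc4ccc(F)c(Cl)c4)ncnc3cc2OC)CC1`: 88.6%
- compound 3, `CCCCCCCCCCCCCCCCOC(=O)CCC(=O)N1CCN(CCCOc2cc3c(Nc4ccc(F)c(Cl)c4)ncnc3cc2OC)CC1`: 82.6%

In a functional assay on A549 cells (Homo sapiens) for cytotoxicity, read by MTT assay, with a stated time of 24 h, tested at 40 uM (on this read-out higher numbers stand for a weaker effect at the one concentration tested and lower numbers for a stronger effect), compound 3 stands second highest of the three numbers; its nearest neighbour is compound 2, a gap within the scatter, and its furthest is compound 1, a gap beyond the scatter. Compound 4, `CCCCCCCCCCCCCCCCCOC(=O)CCC(=O)N1CCN(CCCOc2cc3c(Nc4ccc(F)c(Cl)c4)ncnc3cc2OC)CC1`, differs from compound 3 by methyl in place of hydrogen on a saturated chain carbon, ten or more bonds along the chain from an oxygen next to a carbonyl group. The step that bears on this is the lengthening a number 6 percentage points lower from compound 2 to compound 3 (within the scatter), which shows a chain extension far from the carbonyl. The larger steps of a number 25 percentage points higher from compound 1 to compound 2 (beyond the scatter) and a number 19 percentage points higher from compound 1 to compound 3 (beyond the scatter) involve a much bigger addition. A further single carbon is therefore expected to produce no change beyond the scatter, a number 0.6 percentage points lower from compound 3 to compound 4 (within the scatter). Compound 4 is estimated at 82%, within a range of 70% to 92%.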

Compound 4, a percentage reported as activity, at one concentration (the size of the read-out at that concentration, not a potency): 85.2%
Beside the measured number, compound 4's estimate is 3.2 percentage points below it; the measured number falls inside the stated range.
By their numbers in this assay, from the lowest: compound 1; then compounds 3, 4 and 2 (each within the scatter of the next).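

Methyl in place of hydrogen at this far end of the chain gives a number 2.6 percentage points higher from compound 3 to compound 4 (within the scatter) and propyl in its place gives a number 3.4 percentage points lower from compound 2 to compound 4 (within the scatter), so compounds 2, 3 and 4 cannot be told apart and this added length has no visible effect. Dodecyl on the shorter chain gives a number 21.6 percentage points higher from compound 1 to compound 4 (beyond the scatter) and so a weaker effect, which leaves compound 1 alone among the four. Nothing measured here explains these numbers. Open, on these data alone, are intermediate chains such as octyl or decyl esters, and whether an amine or a carboxylic acid at the chain end would alter the effect.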